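Swapping the Chlorocyanophenyl Arm for a Dichlorothiophene

The compounds below may be only part of what the source reports. "The series", "measured", "known", "first", "only" and "open" are said of these compounds alone.

Measured compounds in a functional assay on MCF7 cells (Homo sapiens) for antiproliferative activity, read by luminescence and CellTiter-Glo, with a stated time of 5 days; on this read-out lower numbers stand for stronger inhibition and higher numbers for weaker inhibition:
Compound 1 `CC/C(=C(/c1ccc(/C=C/C(=O)O)cc1)c1[nH]c2ccccc2c1Cl)c1ccc(Cl)cc1C#N` gives 0.97 nM.
Compound 2 `CC/C(=C(/c1ccc(/C=C/C(=O)O)cc1)c1[nH]c2ccccc2c1Cl)c1ccsc1C#N` gives 7.56 nM.

Compound 1 stands at the lower of the two numbers, so it is the stronger inhibitor of the pair. Going by the values given here, the only measured step from it is a 7.8-fold higher number from compound 1 to compound 2 (0.89 log units; beyond the scatter), where a 2-cyanothiophen-3-yl took the place of the 4-chloro-2-cyanophenyl. Compound 3 `CC/C(=C(/c1ccc(/C=C/C(=O)O)cc1)c1[nH]c2ccccc2c1Cl)c1cc(Cl)sc1Cl` has not yet been measured in this assay. It differs from compound 1 by 2,5-dichlorothiophen-3-yl in place of 4-chloro-2-cyanophenyl on a double-bonded chain carbon bound to a double-bonded chain carbon and a saturated chain carbon. The measured step bears on this change only in part: it also moves from the six-membered ring to the five-membered thiophene, but there the nitrile stayed and the chlorine left, whereas in compound 3 chlorine stays and the nitrile leaves. A modest rise in number, meaning weaker inhibition, is therefore expected, somewhat smaller than the measured step. Compound 3 is estimated at 4 nM, with a range from 1.2 nM to 15 nM. That estimate corresponds to an expected step of a 4.1-fold higher number from compound 1 to compound 3 (0.62 log units; beyond the scatter).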

Compound 3, half-maximal inhibitory concentration: 20 nM
The estimate for compound 3 lay 5.0-fold (0.70 log units) below the measured number, outside the stated range (above it).
By their numbers in this assay, from the lowest: compound 1; then compound 2; then compound 3.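

In this assay, the 2,5-dichlorothiophen-3-yl arm gives a 21-fold higher number from compound 1 to compound 3 (1.31 log units; beyond the scatter) and so marks the largest loss seen at this position. The comparison between the two thiophenes adds something the first step could not show: with the ring size held, 2,5-dichlorothiophen-3-yl in place of 2-cyanothiophen-3-yl still gives a 2.6-fold higher number from compound 2 to compound 3 (0.42 log units; beyond the scatter) and so the two chlorines do not match the single nitrile here. No measurement at hand explains this difference.

The compounds shown leave open how much of the loss belongs to the five-membered ring and how much to the change of substituents. A phenyl ring carrying two chlorines and no nitrile, or a thiophene carrying both a chlorine and a nitrile, would help separate those two contributions.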